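Removing one dimethylaminopropyl chain from compound 3

The compounds below may be only part of what the source reports. "The series", "measured", "known", "first", "only" and "open" are said of these compounds alone.

Measured so far:
- compound 1 `Oc1ccc(-c2cncc(-c3cc4cc(O)ccc4[nH]3)c2)cc1`: 14500 nM
- compound 2 `CN(C)CCn1c(-c2cncc(-c3cc4cc(O)ccc4n3CCN(C)C)c2)cc2cc(O)ccc21`: 14800 nM
- compound 3 `CN(C)CCCn1c(-c2cncc(-c3cc4cc(O)ccc4n3CCCN(C)C)c2)cc2cc(O)ccc21`: 11100 nM

In a functional assay on CCRF-CEM cells (Homo sapiens) for cytotoxicity (a lower number here means a stronger inhibitor, a higher number a weaker inhibitor), compound 3 gives the lowest of the three numbers, yet both compound 1 and compound 2 lie within the scatter of it, so no order can be read from these three.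

Compound 4 `CN(C)CCCn1c(-c2cncc(-c3cc4cc(O)ccc4[nH]3)c2)cc2cc(O)ccc21` is not yet measured. It differs from compound 3 by hydrogen in place of 3-(dimethylamino)propyl on an aromatic nitrogen. Compound 1, with hydrogen on both aromatic nitrogens, and compound 3, with the chain on both, sit within the scatter of each other in this assay; the same spread is expected here. The expected step from compound 3 to compound 4 is therefore a 1.1-fold higher number from compound 3 to compound 4 (0.05 log units; within the scatter), none beyond the scatter. Compound 4 is estimated at 12500 nM, with a range of 6000 nM to 25000 nM.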

Compound 4, half-maximal inhibitory concentration: 14200 nM
Estimate against measurement, compound 4: 1.1-fold (0.06 log units) below; the range from low to high includes it.
By their numbers in this assay, from the lowest: compounds 3, 4, 1 and 2 (each within the scatter of the next).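

In this assay, this first pair differing in one place gives a 1.3-fold higher number from compound 3 to compound 4 (0.11 log units; within the scatter), so hydrogen in place of one 3-(dimethylamino)propyl chain on the aromatic nitrogen makes no readable difference. Compound 4 keeps one chain, and compound 3 shows no measurable gain from carrying a second one. No measurement at hand accounts for this result. Going by these compounds, whether a carboxylic acid, a primary amine or a longer chain on this nitrogen would move the number beyond the scatter remains open.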